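The source may report more compounds than this note shows. Statements on the series, on what has been measured and on what is new or still open speak of the compounds shown alone.

Measured in a toxicity assay on THP-1 cells (Homo sapiens) for inhibition (on this read-out lower numbers stand for higher toxicity in this test and higher numbers for lower toxicity in this test), so far:
- compound 1 `COc1ccc(-c2cnc(NC(=O)c3cccnc3)n2C)cc1` gives > 100000 nM as a limit
- compound 2 `COc1cccc(-c2cnc(NC(=O)c3ccc(F)cc3)n2C)c1` gives > 100000 nM as a limit
- compound 3 `Cn1c(-c2ccccc2)cnc1NC(=O)c1ccccc1` gives > 100000 nM as a limit

Compound 1 has no number, only the limit > 100000 nM in this assay on record. The whole set rests on the limit of > 100000 nM in this assay, at which 3 of the 3 values shown sit, and so offers no graded values.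

Compound 4 `COc1ccc(-c2cnc(NC(=O)c3cccc(O)c3)n2C)cc1` keeps the core of compound 1 and changes one group, with 3-hydroxyphenyl in place of pyridin-3-yl on a carbonyl carbon. Going by the values given here, no step between measured compounds shows what a change at this place does. The expected change (a number no higher from compound 1 to compound 4 (the limit leaves the size open)) is none beyond the scatter in either direction, and this expectation rests only on the limit of > 100000 nM in this assay, at which 3 of the 3 values shown sit, as its guide. Compound 4 is estimated at 100000 nM with an expected range from 40000 nM to 200000 nM in this read-out, and it is likely to be reported as a limit again.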

Compound 4, half-maximal cytotoxic concentration: > 100000 nM
Compound 4: only a limit was reported; the forecaster's own chance of this, stated with the estimate: 80%; the middle value lies on the limit itself.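

Compound 4, like compound 1, is reported in this assay only as a limit, so the step between them cannot be read. The compounds shown leave open which structural change, if any, would bring a graded value in this assay, and they offer only this: the limit of > 100000 nM in this assay, at which 4 of the 4 values shown sit.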